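Dimethylphenyl isomers on the sulfonamide nitrogen

The compounds below may be only part of what the source reports. "The series", "measured", "known", "first", "only" and "open" are said of these compounds alone.

Values in a functional assay on MCF7 cells (Homo sapiens) for antiproliferative activity, read by sulforhodamine B assay, with a stated time of 48 h; a lower number here means a stronger inhibitor, a higher number a weaker inhibitor:
- compound 1 `O=C1NCCN1c1ccc(S(=O)(=O)Nc2ccc(Br)cc2)cc1`: 240 nM
- compound 2 `Cc1cccc(NS(=O)(=O)c2ccc(N3CCNC3=O)cc2)c1C`: 230 nM

For the measured compounds named here, compound 2 stands level with compound 1, the only other measured compound. Compound 3 `Cc1ccc(NS(=O)(=O)c2ccc(N3CCNC3=O)cc2)c(C)c1` is still unmeasured and has the same atoms as compound 2, joined differently: 2,4-dimethylphenyl in place of 2,3-dimethylphenyl on a sulfonamide nitrogen. Going by the values given here, one measured step bears on this change, as it also exchanges the group on the sulfonamide nitrogen, and it stays small: a 1.0-fold lower number from compound 1 to compound 2 (0.02 log units; within the scatter). With so little data, no shift beyond the scatter is expected in this assay. The expected step is a 1.0-fold higher number from compound 2 to compound 3 (0.02 log units; within the scatter). The estimate for compound 3 is 240 nM, with an expected range of 110 nM to 520 nM.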

Compound 3, half-maximal inhibitory concentration: 230 nM
Estimate against measurement, compound 3: 1.0-fold (0.02 log units) above; measured number inside the range.
By their numbers in this assay, from the lowest: compounds 2, 3 and 1 (each within the scatter of the next).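

In this assay, exchanging the 2,3-dimethylphenyl on the sulfonamide nitrogen for 2,4-dimethylphenyl gives no change at the digits printed from compound 2 to compound 3 (within the scatter), so this pair of dimethylphenyl isomers cannot be told apart here. Against the 4-bromophenyl group, the 2,4-dimethylphenyl group gives a 1.0-fold lower number from compound 1 to compound 3 (0.02 log units; within the scatter), matching what the 2,3-dimethylphenyl isomer showed. No supporting data explain this result.

Still open, on these data alone, is whether the sulfonamide nitrogen tolerates a more different group, such as a phenyl ring carrying an amine or a carboxylic acid. As far as these compounds go, a longer alkyl chain in place of the aryl group is equally open.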